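Aryl ester series on the shared core: trifluoromethyl against methyl

The source may report more compounds than this note shows. Statements on the series, on what has been measured and on what is new or still open speak of the compounds shown alone.

Compound 1, `CC1=CC[C@H](C(C)C)c2cc(C)c(OC(=O)c3ccc(C)cc3)cc21`: 100%
Compound 2, `CC1=CC[C@H](C(C)C)c2cc(C)c(OC(=O)c3ccc(C(F)(F)F)cc3)cc21`: 9%
Compound 3, `CC1=CC[C@H](C(C)C)c2cc(C)c(OC(=O)c3cccc(C(F)(F)F)c3)cc21`: 45.5%

In a functional assay on K562 cells (Homo sapiens) for antiproliferative activity, read by sulforhodamine B assay, with a stated time of 48 h, tested at 50 uM (on this read-out lower numbers stand for less inhibition and higher numbers for more inhibition at the one concentration tested (going by the name of the read-out)), compound 1 gives 100%, compound 2 gives 9% and compound 3 gives 45.5%. Compound 2 and compound 3 have the same atoms joined differently; the difference between the two cores is not broken down here. Compound 1 differs from compound 2 in one place, (methyl in place of trifluoromethyl on an aromatic carbon), and the step there is a number 91 percentage points higher from compound 2 to compound 1 (beyond the scatter). Compound 4, `CC1=CC[C@H](C(C)C)c2cc(C)c(OC(=O)c3cccc(C)c3)cc21`, still to be measured, differs from compound 3 by methyl in place of trifluoromethyl on an aromatic carbon. Among these compounds the change occurs two times in all. It is the same kind of change, not the same: in one case the group sits para to a large group, in the other meta to a large group. A step of a number 39.5 percentage points higher from compound 3 to compound 4 (beyond the scatter) is expected because a number 91 percentage points higher from compound 2 to compound 1 (beyond the scatter) was large, and the number in this assay can rise no higher than the top of the percentage scale. Compound 4 is expected at 85%, between 50% and 100%.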

Compound 4, a percentage reported as inhibition, at one concentration (the size of the read-out at that concentration, not a potency): "not active" (no number reported)
No number was reported for compound 4; the estimate stays without a comparison.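

For the compounds shown here, compound 4 is reported as "not active" without a number, so no step from compound 3 to compound 4 can be read. The compounds shown leave open what methyl in place of trifluoromethyl does meta to a large group. No evidence bears on this result.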